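This account rests on a few compounds, and the source may have more. Where it says the series, first, only, none or still open, it means among the compounds named here.

Measured so far:
Compound 1 `C=CCOc1cc(Br)ccc1C(=O)c1cccnc1`: 98000 nM
Compound 2 `O=C(c1cccnc1)c1cc(F)ccc1O`: 6210 nM
Compound 3 `O=C(c1cccnc1)c1ccccc1O`: 33700 nM

In a functional assay on IMR-32 cells (Homo sapiens) for cytotoxicity, read by sulforhodamine B assay, with a stated time of 48 h (on this read-out higher numbers stand for weaker inhibition and lower numbers for stronger inhibition), compound 3 gives 33700 nM, the middle of the three numbers. Compound 4 `O=C(c1cccnc1)c1ccc(Br)cc1O` has bromo in place of hydrogen on an aromatic carbon of compound 3: bromo in place of hydrogen on an aromatic carbon. The closest measured change is a 5.4-fold higher number from compound 2 to compound 3 (0.73 log units; beyond the scatter), where hydrogen replaces fluoro. Read in reverse, that step suggests that adding a halogen lowers the number. It concerns fluoro rather than bromo, on a different carbon, so it guides only loosely. Compound 1 also carries bromo and gives 98000 nM, but it differs elsewhere too. A smaller drop is therefore expected, an estimated 2.2-fold lower number from compound 3 to compound 4 (0.35 log units; beyond the scatter). The expected value for compound 4 is 15000 nM, with an estimated range from 4500 nM to 50000 nM.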

Compound 4, half-maximal inhibitory concentration: 89000 nM
The estimate for compound 4 lay 5.9-fold (0.77 log units) below the measured number; measured number outside the range, above it.
By their numbers in this assay, from the lowest: compound 2; then compound 3; then compounds 4 and 1 (each within the scatter of the next).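

In this assay, placing bromo on this carbon, meta to a hydroxy group and para to a group of 8 heavy atoms, gives a 2.6-fold higher number from compound 3 to compound 4 (0.42 log units; beyond the scatter) and shows that adding a halogen need not lower the number, as fluoro did on another carbon in compound 2. Replacing allyl on the oxygen with hydrogen gives a 1.1-fold lower number from compound 1 to compound 4 (0.04 log units; within the scatter) so, with bromo present, that swap leaves no clear difference. No measurement here explains the effect of bromo.

Going by these compounds, it remains open whether an amine or a methoxy group on this carbon would raise the number as well. Bromo on the carbon that carries fluoro in compound 2 also remains untested among these compounds.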